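This account rests on a few compounds, and the source may have more. Where it says the series, first, only, none or still open, it means among the compounds named here.

Measured compounds:
- compound 1, `O=C(O)CCc1ccc(C#CC2CCCC2)cc1`, in a functional assay on 1321-N1 cells for agonist activity at Free fatty acid receptor 1 (Homo sapiens), read by calcium flux, with a stated time of 0.4 s (a higher number here means that more compound is needed for the effect, a lower number that less compound is needed), compound 1 gives 490 nM
- compound 2, `C/C=C(/C)C#Cc1ccc(CCC(=O)O)c(F)c1`, compound 2 gives 20.4 nM; 20 nM (2 entries)
- compound 3, `C/C=C\C#Cc1ccc(CCC(=O)O)c(F)c1`, compound 3 gives 47.9 nM

Among the compounds with a single number in this assay, compound 3 holds the lowest one; its nearest neighbour is compound 1, whose number is higher by a gap that lies beyond the usual scatter. Compound 2 was measured more than once, and the closeness of its entries, (the several entries of compound 2 in this assay, 20.4 nM; 20 nM (2 entries)), shows how steady repeated measurements can be here.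

The next compound, compound 4, is `C/C=C/C#Cc1ccc(CCC(=O)O)c(F)c1`. Set against compound 3, (the two compounds have the same atoms and bonds and differ only in configuration as drawn: 1 of 1 stereo elements differ; a double bond is drawn Z in compound 3 and E in compound 4). In words: the two compounds have the same atoms and bonds and differ only in configuration as drawn; a double bond is drawn Z in compound 3 and E in compound 4. Within the data shown here, no pair of measured compounds in this set differs in only such a way, so there is no measured step to lean on for the size or direction of the change.

With nothing to point either way, the expected step from compound 3 to compound 4 is a 1.2-fold lower number from compound 3 to compound 4 (0.08 log units; within the scatter), which means no change beyond the scatter is expected. Compound 4 is therefore estimated to give about 40 nM in this assay, within a range from 12 nM to 130 nM.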

Compound 4, half-maximal effective concentration: 209 nM
Beside the measured number, compound 4's estimate is 5.2-fold (0.72 log units) below it; the measured number lies above the stated range.
By their numbers in this assay, from the lowest: compound 3; then compound 4; then compound 1.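

The set now holds its first step between compounds that differ in one place, a 4.4-fold higher number from compound 3 to compound 4 (0.64 log units; beyond the scatter) in this assay, and it shows that the geometry of a single double bond is enough to move the number beyond the scatter. At this position the Z form needs less compound for the effect than the E form, so two compounds with identical atoms and bonds cannot be treated as interchangeable here, and the way a structure is drawn carries real information. The step can be laid on that double bond alone, because nothing else changes between the two compounds: the fact that compounds 3 and 4 differ only in the configuration as drawn

From the compounds shown here alone, this is still one pair giving one direction for one double bond, so it remains open whether the Z form would keep its edge if that double bond carried a longer chain or a nitrile. Among these compounds, what lies behind the gap also stays unknown, as the pair has only the one read-out in this assay, which gives a size and a direction but no explanation.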